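Fluoro Added to Compound 3: Expected Tolerance in Macrophage Cells

This account rests on a few compounds, and the source may have more. Where it says the series, first, only, none or still open, it means among the compounds named here.

Compound 1, `O=[N+]([O-])c1ccc(O[C@H]2CCCC[C@@H]2Cn2ccnc2)c(F)c1`, gives > 100 ug/mL in an ADME assay on J774.A1 cells (Mus musculus) for cytotoxicity, with a stated time of 48 h; a higher number here means that more compound is tolerated, a lower number that less compound is tolerated; that value is a limit of this assay.
Compound 2, `FC(F)(F)c1ccc(OC2C(n3ccnc3)CCCC2n2ccnc2)cc1`, gives 96.4 ug/mL in this assay.
Compound 3, `O=[N+]([O-])c1ccc(OC2C(n3ccnc3)CCCC2n2ccnc2)cc1`, gives > 100 ug/mL in this assay; that value is a limit of this assay.

Compound 3 thus stands at the top of the numbers shown, with only a limit and no number for it, and it shares that position with compound 1, as the limit of > 100 ug/mL in this assay, at which 2 of the 3 values shown sit, records. For the measured compounds named here, the single measured step, an at least 1.0-fold higher number from compound 2 to compound 3 (0.01 log units; that floor lies within the scatter), lies within the scatter and so gives no sign that the aromatic substituent moves the read-out.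

Compound 4, `O=[N+]([O-])c1ccc(OC2C(n3ccnc3)CCCC2n2ccnc2)c(F)c1`, differs from compound 3 by fluoro in place of hydrogen on an aromatic carbon. Going by the values given here, no measured step covers this change directly, but compound 1 already carries a fluoro on the same position and sits at the limit. The expectation for compound 4 is therefore a step that the limit leaves unreadable from compound 3 to compound 4, none beyond the scatter, with the value most likely again reported as a limit. Compound 4 is estimated at 110 ug/mL, with a range from 60 ug/mL to 200 ug/mL.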

Compound 4, half-maximal cytotoxic concentration: 90.6 ug/mL
For compound 4 the middle estimate is 1.2-fold (0.08 log units) above the measured one, and the stated range covers the measured number.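

Among the nitro compounds shown, only compound 4 gives a number and not a limit in this assay (90.6 ug/mL), so fluoro on this aromatic carbon, ortho to a large group and meta to a nitro group, yields the first readable value for this substitution. Compound 3 gives a limit (> 100 ug/mL) and not a number. The change therefore reads as an at least 1.1-fold lower number from compound 3 to compound 4 (0.04 log units; that floor lies within the scatter) and shows no step beyond the scatter, but that figure is only a floor, and the full size of the step stays unread because compound 3 sits at the top of the range: the limit of > 100 ug/mL in this assay, at which 2 of the 4 values shown sit.

On these data alone, whether chloro, methoxy or an amine on the same aromatic carbon would shift the read-out stays open. So does whether fluoro at this place behaves alike when trifluoromethyl replaces the nitro group.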